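Chloro in Place of Methyl: An Expected Liver Extraction

The compounds below may be only part of what the source reports. "The series", "measured", "known", "first", "only" and "open" are said of these compounds alone.

The study concerns two close relatives on a shared core. Compound 1 `CCC(CC)n1c(=O)[nH]c2nccnc21` carries no group on the aromatic carbon in question, and in an ADME assay on microsomes from liver (Homo sapiens), read by LC-MS, with a stated time of 90 min (a lower number here means that the liver removes a smaller share, a higher number that the liver removes a larger share of the compound in one pass), compound 1 gives "not determined" (no result reported). Compound 2 `CCC(CC)n1c(=O)[nH]c2ncc(C)nc21` carries a methyl there. In this assay compound 2 gives < 0.2, which is a limit of the assay rather than a number. Going by the values given here, this is where compound 2 stands: the one numerical entry is a limit (the limit of < 0.2 in this assay, at which 1 of the 2 values shown sits), and the other entry carries no number at all, so no measured step between compounds is available.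

The step of interest leads to compound 3 `CCC(CC)n1c(=O)[nH]c2ncc(Cl)nc21`, which differs from compound 2 by chloro in place of methyl on an aromatic carbon. Among the compounds with values here, with no measured step to lean on, the account rests on the limit alone. Compound 3 is expected to stay close to compound 2, so the step from compound 2 to compound 3 is estimated as a number no lower from compound 2 to compound 3 (the limit leaves the size open), a change that does not go beyond the scatter. Compound 3 is therefore estimated at 0.2 in this assay, expected to lie between 0.1 and 0.35.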

Compound 3, hepatic extraction ratio: < 0.2
Compound 3 was reported as a limit; the forecaster's own chance of this, stated with the estimate: 45%; the middle value sits exactly at the limit.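

In this assay compound 3, like compound 2, is reported only as a limit and not as a number, so no step between compound 2 and compound 3 can be read: the limit of < 0.2 in this assay, at which 2 of the 3 values shown sit.

The compounds shown leave open where either compound truly lies, and whether chloro in place of methyl on an aromatic carbon changes the share the liver removes at all.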